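The source may report more compounds than this note shows. Statements on the series, on what has been measured and on what is new or still open speak of the compounds shown alone.

Compound 1 `O=c1[nH]cnc2c1c(-c1ccoc1)cn2[C@@H]1O[C@H](CO)[C@@H](O)[C@H]1O`: 9030 nM
Compound 2 `O=c1[nH]cnc2c1c(-c1ccco1)cn2[C@@H]1O[C@H](CO)[C@@H](O)[C@H]1O`: > 20000 nM
Compound 3 `COc1nc(N)nc2c1c(-c1ccoc1)cn2[C@@H]1O[C@H](CO)[C@@H](O)[C@H]1O`: > 20000 nM

All three compounds were tested in a functional assay on CCRF-CEM cells (Homo sapiens), read by MTT assay, with a stated time of 72 h; a higher number here means a weaker inhibitor, a lower number a stronger inhibitor. In this assay compound 1 gives 9030 nM, a real number. For compound 2 the value > 20000 nM is a limit of this assay and not a number. For compound 3 the value > 20000 nM is likewise a limit, not a number.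

Compound 1 and compound 2 share one core and differ in a single place: furan-2-yl in place of furan-3-yl on an aromatic carbon. That change produced an at least 2.2-fold higher number from compound 1 to compound 2 (0.34 log units; beyond the scatter). Compound 3 carries a different core; how its core differs from the core of compound 1 is not broken down here.

Compound 4 `COc1nc(N)nc2c1c(-c1ccco1)cn2[C@@H]1O[C@H](CO)[C@@H](O)[C@H]1O` has not yet been measured. It differs from compound 3 by the same change, (furan-2-yl in place of furan-3-yl on an aromatic carbon), at a place described in the same words as before. Compound 3 is already at the limit of > 20000 nM in this assay, at which 2 of the 3 values shown sit. Because the same change gave an at least 2.2-fold higher number from compound 1 to compound 2 (0.34 log units; beyond the scatter), compound 4 is expected to remain at or beyond that limit, so a further weakening is expected. The expected step is a step that the limit leaves unreadable from compound 3 to compound 4. The estimate for compound 4 in this assay is 45000 nM, expected to fall between 18000 nM and 150000 nM.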

Compound 4, half-maximal inhibitory concentration: > 20000 nM
Compound 4 was reported as a limit; the forecaster's own chance of this, stated with the estimate: 90%; the middle value is on the limit's open side.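

In this assay compound 4 gives > 20000 nM, a limit and not a number. Compound 3 and compound 4 therefore yield no readable step, since both stand at the same end of the scale: the limit of > 20000 nM in this assay, at which 3 of the 4 values shown sit.

The compounds shown leave open whether furan-2-yl in place of furan-3-yl changes anything on the core of compound 3, and by how much.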